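Trifluoromethyl to methyl: an expected step within the scatter

A few compounds are considered here, and "the series" means these few. Any claim that something is new, unique, unknown or untested is made for them only; others in the source may bear on it.

Three compounds have been measured in a functional assay on NCI-H460 cells (Homo sapiens) for cytotoxicity, read by MTT assay, with a stated time of 68 h (on this read-out higher numbers stand for weaker inhibition and lower numbers for stronger inhibition), so far:
compound 1 `O=C(Nc1cccc(-c2cccc(F)c2)c1)C(Cl)Cl` gives > 50000 nM (a limit of the assay, not a number)
compound 2 `COc1cccc(-c2cccc(NC(=O)C(Cl)Cl)c2)c1` gives 33800 nM
compound 3 `O=C(Nc1cccc(-c2cccc(C(F)(F)F)c2)c1)C(Cl)Cl` gives 30200 nM

Among the compounds with values here, of these three values only two are numbers, and compound 3 holds one of them. The gap to the other is a 1.1-fold lower number from compound 2 to compound 3 (0.05 log units; within the scatter) and so gives the two no order.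

Compound 4 `Cc1cccc(-c2cccc(NC(=O)C(Cl)Cl)c2)c1` keeps the shared core and differs from compound 3 in one place: methyl in place of trifluoromethyl on an aromatic carbon. Within the data shown here, no measured step makes this exact exchange, so the nearest evidence is the other exchanges on that aromatic carbon. The steps of an at least 1.4-fold lower number from compound 1 to compound 2 (0.17 log units; that floor lies within the scatter) and an at least 1.6-fold lower number from compound 1 to compound 3 (0.21 log units; that floor lies within the scatter) both start from the limit held by compound 1, so they give floors and not sizes.

With methoxy in compound 2 and trifluoromethyl in compound 3 standing level (a 1.1-fold lower number from compound 2 to compound 3 (0.05 log units; within the scatter)), no change beyond the scatter is expected for methyl in either direction. The expected step is a 1.2-fold higher number from compound 3 to compound 4 (0.06 log units; within the scatter) and has no firm direction. A reading that reaches only the limit of this assay remains possible. For compound 4 the expectation is an estimated value of 35000 nM (range 18000 nM to 50000 nM).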

Compound 4, half-maximal inhibitory concentration: 24300 nM
For compound 4 the middle estimate is 1.4-fold (0.16 log units) above the measured one; low and high end bracket the measured number.
By their numbers in this assay, from the lowest: compounds 4, 3 and 2 (each within the scatter of the next). At a limit, above all of these: compound 1.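

In (this assay), methyl on this aromatic carbon, meta to a large group, does not separate from trifluoromethyl (a 1.2-fold lower number from compound 3 to compound 4 (0.09 log units; within the scatter)) or from methoxy (a 1.4-fold lower number from compound 2 to compound 4 (0.14 log units; within the scatter)), so three different groups at this position now stand level. Within the data shown here, the new information lies in the exchange of fluoro for methyl (an at least 2.0-fold lower number from compound 1 to compound 4 (0.31 log units; beyond the scatter)), the first step at this position whose floor lies beyond the scatter, whereas the floors of the two earlier steps from compound 1 lay within it. This step gives only a floor, and its true size cannot be read, as compound 1 stands at a limit of the assay and not at a number: (the limit of > 50000 nM in this assay, at which 1 of the 4 values shown sits).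

On these data alone, how far compound 1 truly lies from compound 2, compound 3 and compound 4 therefore stays open. The compounds shown also leave open whether an amine, a carboxylic acid or a longer chain at this position would give a number beyond the scatter of these three, or whether the values at this position stay level with other groups as well.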